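A few compounds are considered here, and "the series" means these few. Any claim that something is new, unique, unknown or untested is made for them only; others in the source may bear on it.

Measured compounds:
compound 1 `CCn1cc(-c2ccc(Cl)cc2)c(=O)c2cc(F)c(N3CCNCC3)cc21`, compound 2 `CCn1cc(-c2ccc(OC)cc2)c(=O)c2cc(F)c(N3CCNCC3)cc21`, compound 3 `O=c1c(-c2cccc(Cl)c2)cn(C2CC2)c2cc(N3CCNCC3)c(F)cc12`.

In a functional assay on HeLa cells (Homo sapiens) for antiproliferative activity, read by MTT assay, with a stated time of 48 h (on this read-out higher numbers stand for weaker inhibition and lower numbers for stronger inhibition), compound 1 gives 15400 nM, compound 2 gives 69000 nM and compound 3 gives 890 nM. Compound 3 stands lowest of the three; the difference between its core and the core of compound 1 is not broken down here. Within the core of compound 1 the change methoxy in place of chloro on an aromatic carbon gave a 4.5-fold higher number from compound 1 to compound 2 (0.65 log units; beyond the scatter). Compound 4 `COc1cccc(-c2cn(C3CC3)c3cc(N4CCNCC4)c(F)cc3c2=O)c1` is not yet measured; it carries the same kind of change on the core of compound 3, (methoxy in place of chloro on an aromatic carbon), but here the group sits meta to a large group, where in compound 2 it sat para to a large group. For the measured compounds named here, the expectation for compound 4 in this assay is a step of a 3.4-fold higher number from compound 3 to compound 4 (0.53 log units; beyond the scatter), resting on compound 1 to compound 2 as the only earlier instance of this change. Compound 4 is estimated at 3000 nM, within 1200 nM to 8000 nM.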

Compound 4, half-maximal inhibitory concentration: 920 nM
Estimate against measurement, compound 4: 3.3-fold (0.51 log units) above, outside the stated range (below it).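

In this assay, methoxy in place of chloro on an aromatic carbon gave a 1.0-fold higher number from compound 3 to compound 4 (0.01 log units; within the scatter), so compound 3 and compound 4 do not separate on this read-out. The change therefore does not carry over with the same size from the core of compound 1 to the core of compound 3: the same change on two cores in this assay, a 4.5-fold higher number (0.65 log units; beyond the scatter) from compound 1 to compound 2 and a 1.0-fold higher number (0.01 log units; within the scatter) from compound 3 to compound 4, 4.3-fold (0.64 log units) apart, beyond the scatter of two such steps This does not show which difference sets the two steps apart, since the pairs differ both in the core and in where the group sits, and two pairs set no rule for the series.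

Still open, going by these compounds, is how an amine or a carboxylic acid at this same place would read on the core of compound 3. Also open, on these data alone, is whether 3-methoxyphenyl on the core of compound 1 would give a step like that of either pair.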